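Cytotoxicity series: furan-substituted spiro core, aryl variation

The source may report more compounds than this note shows. Statements on the series, on what has been measured and on what is new or still open speak of the compounds shown alone.

Measured compounds and values:
compound 1 `CC1(C)OC(=O)C2(C(=O)O1)[C@@H](c1ccco1)CC(=O)C[C@H]2c1c[nH]c2ccccc12` – > 111000 nM
compound 2 `CC1(C)OC(=O)C2(C(=O)O1)[C@@H](c1ccco1)CC(=O)C[C@H]2c1ccccc1Cl` – > 111000 nM
compound 3 `COc1ccc([C@@H]2CC(=O)C[C@H](c3ccco3)C23C(=O)OC(C)(C)OC3=O)c(C)c1` – > 111000 nM

Compound 1 stands only at a limit of the assay in an ADME assay on MT2 cells (Homo sapiens) for cytotoxicity; on this read-out lower numbers stand for higher toxicity in this test and higher numbers for lower toxicity in this test: its value of > 111000 nM is a limit and not a number. The same holds for compound 2, whose value in this assay is also a limit. Compound 3 likewise gives only a limit in this assay. Every measured value here is the limit of > 111000 nM in this assay, at which 3 of the 3 values shown sit.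

The change under consideration is 2,3-dimethoxyphenyl in place of 1H-indol-3-yl on a saturated ring carbon, giving compound 4 `COc1cccc([C@@H]2CC(=O)C[C@H](c3ccco3)C23C(=O)OC(C)(C)OC3=O)c1OC`. For the measured compounds named here, the steps that bear on it are the other aryl replacements on the same saturated ring carbon: a step that the two limits leave unreadable from compound 1 to compound 2, a step that the two limits leave unreadable from compound 1 to compound 3 and a step that the two limits leave unreadable from compound 2 to compound 3. On these data alone, none of them is readable, so their size is unknown; what they do show is that none of the three aryl groups so far brought the value of any compound below the limit.

Compound 4 is therefore expected to give a value of about 150000 nM, within 111000 nM to 300000 nM, most likely again reported as a limit. The implied estimated step that the limit leaves unreadable from compound 1 to compound 4 is expected to be none beyond the scatter.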

Compound 4, half-maximal cytotoxic concentration: > 111000 nM
Compound 4 gave a limit, no number; the forecaster's own chance of this, stated with the estimate: 85%; the middle value is on the limit's open side.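

No step from compound 1, compound 2 or compound 3 to compound 4 can be read, since each pair gives only a limit and not a number: the limit of > 111000 nM in this assay, at which 4 of the 4 values shown sit.

The compounds shown leave open where any true value lies in this assay, and whether changing the aryl group on this saturated ring carbon moves it at all.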